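The source may report more compounds than this note shows. Statements on the series, on what has been measured and on what is new or still open speak of the compounds shown alone.

Compound 1 `CCCCOc1ccc(-c2c(NC(C)(C)CC(C)(C)C)nc3ncccn23)cc1`: 49000 nM
Compound 2 `CCCCOc1ccc(-c2c(N)nc3ncccn23)cc1`: > 100000 nM
Compound 3 `Nc1c(-c2ccc(Br)cc2)nc2ncccn12`: > 100000 nM

The three compounds were tested in a toxicity assay on A549 cells (Homo sapiens) for cytotoxicity, read by luminescence and CellTiter-Glo, with a stated time of 48 h; a higher number here means that more compound is tolerated, a lower number that less compound is tolerated. In this assay compound 1 gives 49000 nM. For compound 2 the assay reports only a limit, > 100000 nM. Compound 3 also stands at a limit, > 100000 nM. Compound 2 therefore has no exact number; it sits at the limit of > 100000 nM in this assay, at which 2 of the 3 values shown sit, together with compound 3. For the measured compounds named here, the one step measured between compounds that differ in a single place is an at least 2.0-fold higher number from compound 1 to compound 2 (0.30 log units; that floor lies within the scatter), so taking the 1,1,3,3-tetramethylbutyl off the ring nitrogen pushed the number up to the limit.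

Compound 4 `Nc1nc2ncccn2c1-c1ccc(Br)cc1` is compound 2 with one change: bromo in place of butoxy on an aromatic carbon. Going by the values given here, no measured step exchanges these two groups, and the only measured step, an at least 2.0-fold higher number from compound 1 to compound 2 (0.30 log units; that floor lies within the scatter), concerns a different place on the molecule. The closest information is compound 3, which also carries bromo on its phenyl ring and sits at a limit. On this basis no step beyond the scatter is expected from compound 2 to compound 4. Compound 4 is expected to give about 100000 nM, with a range from 50000 nM to 200000 nM. The expected step is a number no higher from compound 2 to compound 4 (the limit leaves the size open).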

Compound 4, half-maximal cytotoxic concentration: > 100000 nM
Compound 4 ended at the assay's limit (the forecaster's own chance of this, stated with the estimate: 75%); the middle value sits exactly at the limit.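

In this assay compound 2 and compound 4 both stand at a limit rather than at an exact number, so no step can be read between them: the limit of > 100000 nM in this assay, at which 3 of the 4 values shown sit. The compounds shown leave open whether bromo in place of butoxy changes how much compound the cells tolerate, and in which direction.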